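A few compounds are considered here, and "the series" means these few. Any claim that something is new, unique, unknown or untested is made for them only; others in the source may bear on it.

In a functional assay on HL-60 cells (Homo sapiens) for cytotoxicity, read by luminescence and CellTiter-Glo, with a stated time of 3 days (on this read-out lower numbers stand for stronger inhibition and higher numbers for weaker inhibition), compound 1 `O=C(Nc1cc(C(F)(F)F)cc(C(F)(F)F)c1)c1cc(Cl)c(-c2ccccc2)cc1O` gives 790 nM, the lowest of the three numbers at hand. Compound 2 `N#Cc1ccc(NC(=O)c2ccc(F)cc2O)cc1` gives 1380 nM, which lies within the usual scatter of the value of compound 1, so the two cannot be put in order. Compound 3 `N#Cc1ccc(NC(=O)c2ccc(-c3cccnc3)cc2O)cc1` gives 6660 nM, a value that stands beyond the scatter from compound 1. Within the data shown here, the only single-point step among the measured compounds is a 4.8-fold higher number from compound 2 to compound 3 (0.68 log units; beyond the scatter), a change of a different kind from the one considered next.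

Compound 4 `O=C(Nc1cc(C(F)(F)F)cc(C(F)(F)F)c1)c1ccc(-c2ccccc2)cc1O` differs from compound 1 in one place: hydrogen in place of chloro on an aromatic carbon. Among the measured compounds shown here, no measured pair shows this change, and the step from compound 2 to compound 3 does not bear on it, so the data say nothing about what the chloro contributes. Since compound 1 sits at the low end of the three values, there is more room for a higher number than for a lower one. Compound 4 is therefore expected to give a number in this assay that is somewhat higher, with a wide range, a step of a 1.9-fold higher number from compound 1 to compound 4 (0.28 log units; within the scatter). The estimate for compound 4 in this assay is 1500 nM, between 500 nM and 4500 nM.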

Compound 4, half-maximal inhibitory concentration: 1140 nM
Compound 4: the middle estimate sits 1.3-fold (0.12 log units) above what was measured, within the range that was stated.
By their numbers in this assay, from the lowest: compounds 1, 4 and 2 (each within the scatter of the next); then compound 3.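

In this assay, hydrogen in place of chloro on the aromatic carbon ortho to a phenyl group and para to a hydroxy group gives a 1.4-fold higher number from compound 1 to compound 4 (0.16 log units; within the scatter), which lies within the scatter, so compound 1 and compound 4 cannot be told apart on this read-out. Among these compounds, this is the first direct look at this position, and it shows that the chloro is not required for a number in this range when the rest of compound 1 stays the same. No measurement is available that could explain this result, whether for the chloro or for the hydrogen at this carbon.

The compounds shown leave open whether this carbon tolerates other groups in the same way, since a single exchange of chloro for hydrogen says nothing about an amine, a carboxylic acid or a longer chain such as a butoxy group placed there. From the compounds shown here alone, it also remains open whether the same exchange would stay within the scatter in a compound lacking the phenyl group or the two trifluoromethyl groups of compound 1 and compound 4.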